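Swapping Chloro for Nitro on Compound 2

The source may report more compounds than this note shows. Statements on the series, on what has been measured and on what is new or still open speak of the compounds shown alone.

Of the compounds shown here, three have been measured in a functional assay on BMDM cells (Mus musculus, strain C57BL/6) for inhibition, with a stated time of 2 days; a higher number here means a weaker inhibitor, a lower number a stronger inhibitor. Compound 2 `CCOC(=O)c1sc(NC(=O)Cn2cc(-c3ccc(Cl)cc3)nn2)nc1C` gives 180 nM, the lowest of the three numbers. In this assay compound 1 `Cc1csc(NC(=O)Cn2cc(-c3cccc(N)c3)nn2)n1` gives 250 nM, which lies within the scatter of compound 2. Within the data shown here, compound 3 `O=C(Cn1cc(-c2ccc([N+](=O)[O-])cc2)nn1)Nc1nc2ccccc2s1` gives 3280 nM, beyond the scatter from compound 2, though no single-change step connects the two. Compound 4 `CCOC(=O)c1sc(NC(=O)Cn2cc(-c3ccc([N+](=O)[O-])cc3)nn2)nc1C` is not yet measured; it differs from compound 2 by nitro in place of chloro on an aromatic carbon. Among the measured compounds shown here, no measured pair isolates this change, so only a modest weakening is expected, a step of a 2.5-fold higher number from compound 2 to compound 4 (0.40 log units; beyond the scatter) in this assay. Compound 4 is therefore estimated at 450 nM, within a range from 150 nM to 1500 nM.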

Compound 4, half-maximal inhibitory concentration: 1840 nM
For compound 4 the middle estimate is 4.1-fold (0.61 log units) below the measured one, outside the stated range (above it).
By their numbers in this assay, from the lowest: compounds 2 and 1 (each within the scatter of the next); then compounds 4 and 3 (each within the scatter of the next).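

In this assay, among these compounds, the change from 4-chlorophenyl to 4-nitrophenyl gives a 10-fold higher number from compound 2 to compound 4 (1.01 log units; beyond the scatter) and is the first measured step to isolate this position. It shows that the number here depends strongly on which of these two groups the ring carries. The earlier compounds differed in more than one place, so none of their gaps could be assigned to a single group, and nothing at hand explains the size of this step. As far as these compounds go, whether a nitrile or a methoxy group at this position would stay near compound 2 or move toward compound 4 remains open. So does whether the same swap would give a step of similar size on the core of compound 1.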